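The source may report more compounds than this note shows. Statements on the series, on what has been measured and on what is new or still open speak of the compounds shown alone.

Measured compounds:
- compound 1, `CO[C@H]1O[C@H](COc2ccccc2C(C)C)[C@@H](O)[C@H](O)[C@H]1Oc1ccc(OC2CCCCC2)cc1`: 36000 nM
- compound 2, `CO[C@@H]1O[C@H](COc2ccccc2C(C)C)[C@@H](O)[C@H](O)[C@H]1Oc1ccc(OC2CCCCC2)cc1`: 44000 nM

In a functional assay on MDA-MB-231 cells (Homo sapiens) for cytotoxicity, read by MTT assay, with a stated time of 48 h (a lower number here means that less compound is needed, a higher number that more compound is needed for the effect), compound 1 gives 36000 nM and compound 2 gives 44000 nM. Going by the values given here, compound 1 carries the numerically smaller of the two numbers, but the only measured step, a 1.2-fold higher number from compound 1 to compound 2 (0.09 log units; within the scatter), lies within the scatter, so the two compounds are not separated by this assay. That step rests on (the fact that compounds 1 and 2 differ only in the configuration as drawn); it touches neither aryl ether and leaves the rest of the core untouched.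

Compound 3, `CO[C@H]1O[C@H](COc2cccc(C(C)C)c2)[C@@H](O)[C@H](O)[C@H]1Oc1ccc(OC2CCCCC2)cc1`, is not yet measured in this assay. It differs from compound 1 by 3-isopropylphenyl in place of 2-isopropylphenyl on an oxygen on a saturated carbon. Among the compounds with values here, no measured step changes the isopropylphenyl ring or any other part of the aryl ethers; the step from compound 1 to compound 2 is a change of configuration only and carries no information on moving the isopropyl group around the ring. With nothing measured that bears on the change, the expectation for compound 3 is a number close to that of compound 1, with a step expected of no change at the digits printed from compound 1 to compound 3 (within the scatter) in this assay, that is none beyond the scatter. Compound 3 is therefore estimated at 36000 nM in this assay, with a range from 14000 nM to 95000 nM.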

Compound 3, half-maximal effective concentration: 38000 nM
For compound 3 the middle estimate is 1.1-fold (0.02 log units) below the measured one, within the range that was stated.
By their numbers in this assay, from the lowest: compounds 1, 3 and 2 (each within the scatter of the next).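

In this assay, moving the isopropyl group on the ring of this aryl ether gives a 1.1-fold higher number from compound 1 to compound 3 (0.02 log units; within the scatter), so 2-isopropylphenyl and 3-isopropylphenyl on an oxygen on a saturated carbon are not separated, whereas the earlier pair spoke only to configuration at a saturated ring carbon. Going by these compounds alone, this is the first measured change to the aryl ether itself: compound 3 at 38000 nM and compound 1 at 36000 nM show that, for this pair, the shift of the isopropyl group alone opens no gap beyond the scatter. Nothing at hand bears on why these two compounds, with the same atoms joined differently, are not separated.

The compounds shown leave open whether another group in place of isopropyl on that ring, such as a carboxylic acid, an amine or a longer alkyl chain, would move the number beyond the scatter. They also leave open whether 3-isopropylphenyl behaves the same way with the configuration drawn in compound 2, and whether a change to the other aryl ether would separate compounds in this assay.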